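Permeability notes: naphthyl replacement at the aromatic carbon of compound 3

A few compounds are considered here, and "the series" means these few. Any claim that something is new, unique, unknown or untested is made for them only; others in the source may bear on it.

The series shares one core, carrying a furanylmethylamine chain and a variable group on the aromatic carbon. Compound 1 `CC(C)Cc1ccc2c(NCCCNCc3ccco3)ccnc2c1` gives 23 10^-6 cm/s in an ADME assay for permeability, using PAMPA, with a stated time of 30 min, at pH 7.4; a lower number here means that the compound crosses the layer more slowly, a higher number that the compound crosses the layer faster. Compound 2 `Fc1ccc(Oc2ccc3c(NCCCNCc4ccco4)ccnc3c2)cc1` gives 317 10^-6 cm/s, and compound 3 `Cc1cc(C)cc(Cc2ccc3c(NCCCNCc4ccco4)ccnc3c2)c1` gives 23 10^-6 cm/s. Compound 3 sits level with compound 1 and, together with it, at the low end of the three numbers; from compound 2 it is separated by the large step of a 14-fold lower number from compound 2 to compound 3 (1.14 log units; beyond the scatter), whereas no change at the digits printed from compound 1 to compound 3 (within the scatter) lies within the scatter.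

Compound 4 `c1coc(CNCCCNc2ccnc3cc(-c4cccc5ccccc45)ccc23)c1` has not been measured. It differs from compound 3 as follows: naphthalen-1-yl in place of 3,5-dimethylbenzyl on an aromatic carbon. For the measured compounds named here, two measured steps bear on this. no change at the digits printed from compound 1 to compound 3 (within the scatter) shows that an isobutyl and a 3,5-dimethylbenzyl give the same reading, while a 14-fold lower number from compound 2 to compound 3 (1.14 log units; beyond the scatter) shows that an aryl group bound to the aromatic carbon through oxygen reads far higher than a benzyl. Compound 4 carries an aryl bound directly to the aromatic carbon, a case between those two, so a modest rise is expected, with wide uncertainty. The step of a 2.2-fold higher number from compound 3 to compound 4 (0.34 log units; beyond the scatter) is the expected outcome. Compound 4 is therefore estimated at 50 10^-6 cm/s, expected to lie between 15 10^-6 cm/s and 170 10^-6 cm/s.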

Compound 4, apparent permeability: 237 10^-6 cm/s
The estimate for compound 4 lay 4.7-fold (0.68 log units) below the measured number; measured number above the stated range.
By their numbers in this assay, from the lowest: compounds 1 and 3 (each within the scatter of the next); then compounds 4 and 2 (each within the scatter of the next).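

Working notes: at this aromatic carbon, the readings in this assay now fall into two levels, with the step of a 10-fold higher number from compound 3 to compound 4 (1.01 log units; beyond the scatter) and the step of a 10-fold higher number from compound 1 to compound 4 (1.01 log units; beyond the scatter) setting the naphthalen-1-yl of compound 4 well apart from the 3,5-dimethylbenzyl and the isobutyl, while the step of a 1.3-fold lower number from compound 2 to compound 4 (0.13 log units; within the scatter) leaves it level with the 4-fluorophenoxy. The high level is thus not confined to an aryl group bound through oxygen: among these four compounds, an aryl group bound directly or through oxygen reads high in compound 4 and compound 2, a group bound through a saturated carbon reads low in compound 1 and compound 3, and no compound shown goes against this. Heavy-atom count does not follow the same division, since the change from compound 3 to compound 4 alters the heavy-atom count only slightly yet crosses from the low level to the high one, and nothing measured here gives a reason for the two levels.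

Open, on these data alone, is whether the high level persists with a plain phenyl, a naphthalen-2-yl or a pyridine ring at this carbon, or with an aryl group bound through sulfur or an amide. Also open, as far as these compounds go, is how an amine or a carboxylic acid on the aryl ring would read.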